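The source may report more compounds than this note shows. Statements on the series, on what has been measured and on what is new or still open speak of the compounds shown alone.

Compound 1 `Fc1ccccc1NC(=S)N/N=C/c1ccc2ccccc2n1`: > 100000 nM, a limit of the assay.
Compound 2 `Cc1ccc(NC(=S)N/N=C/c2ccc3ccccc3n2)cc1`: 92900 nM.

Among the compounds with values here, in a functional assay on SGC-7901 cells (Homo sapiens) for antiproliferative activity, read by sulforhodamine B assay, with a stated time of 72 h (a lower number here means a stronger inhibitor, a higher number a weaker inhibitor), compound 2 gives 92900 nM, the only actual number so far. For compound 1, the assay reports only a limit, > 100000 nM. The other result is thus (the limit of > 100000 nM in this assay, at which 1 of the 2 values shown sits).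

The next compound is compound 3 `Fc1ccc(NC(=S)N/N=C/c2ccc3ccccc3n2)cc1`. It differs from compound 2 by fluoro in place of methyl on an aromatic carbon, with fluoro in place of methyl on an aromatic carbon, para to a large group. Within the data shown here, the one measured step that bears on this is an at least 1.0-fold lower number from compound 1 to compound 2 (0.03 log units; that floor lies within the scatter). It also exchanges fluoro-bearing and methyl-bearing groups, but there the group is 2-fluorophenyl, not 4-fluorophenyl, and its size is only a floor within the scatter. The expected step in this assay is therefore a 1.0-fold lower number from compound 2 to compound 3 (0.01 log units; within the scatter), in no clear direction and not beyond the scatter. The estimate for compound 3 is 90000 nM, with an expected range of 40000 nM to 180000 nM.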

Compound 3, half-maximal inhibitory concentration: 32300 nM
Beside the measured number, compound 3's estimate is 2.8-fold (0.45 log units) above it; the measured number lies below the stated range.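

In this assay, the para substituent on the phenyl ring proves able to shift the read-out: fluoro in place of methyl gives a 2.9-fold lower number from compound 2 to compound 3 (0.46 log units; beyond the scatter), whereas the earlier pair offered only a floor within the scatter. The place of the fluoro also counts, since 4-fluorophenyl in place of 2-fluorophenyl gives an at least 3.0-fold lower number from compound 1 to compound 3 (0.49 log units; beyond the scatter). Compound 1 gives only a limit, so this second step is a floor and its full size stays unknown: the limit of > 100000 nM in this assay, at which 1 of the 3 values shown sits.

The compounds shown leave open how a chloro group, a methoxy group or an amine at this same place would compare with fluoro and methyl. They also cannot tell why fluoro and methyl differ here, and even compound 3 is compared only within this small set of three.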